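A Pyrazole Swap on a Weak Thiazole Amide

The source may report more compounds than this note shows. Statements on the series, on what has been measured and on what is new or still open speak of the compounds shown alone.

In a functional assay on KM12 cells (Homo sapiens) for inhibition, read by colorimetric assay and sulforhodamine B assay, with a stated time of 48 h (a lower number here means a stronger inhibitor of growth, a higher number a weaker inhibitor of growth), compound 1 `CCCCCCCCCCCC[C@@H](O)[C@H]1CC[C@H]([C@H](O)CCCCCCCCCCNC(=O)c2cccs2)O1` gives 3090 nM, while compound 2 `CCCCCCCCCCCC[C@@H](O)[C@H]1CC[C@H]([C@H](O)CCCCCCCCCCNC(=O)c2cncs2)O1` gives 100000 nM, the higher of the two numbers. Compound 3 `CCCCCCCCCCCC[C@@H](O)[C@H]1CC[C@H]([C@H](O)CCCCCCCCCCNC(=O)c2ccnn2C)O1` carries one change from compound 2: 1-methyl-1H-pyrazol-5-yl in place of 1,3-thiazol-5-yl on a carbonyl carbon. Among the compounds with values here, only one measured step bears on this place, a 32-fold higher number from compound 1 to compound 2 (1.51 log units; beyond the scatter), and it was large, showing that swapping this ring alone can shift this assay strongly. The expected step is a 3.3-fold lower number from compound 2 to compound 3 (0.52 log units; beyond the scatter), a smaller move towards a lower number. For compound 3 the estimate is 30000 nM, with an expected range of 6000 nM to 100000 nM.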

Compound 3, concentration for 50% growth inhibition: 100000 nM
Compound 3: middle estimate off by 3.3-fold (0.52 log units), on the low side; the measured number falls inside the stated range.
By their numbers in this assay, from the lowest: compound 1; then compounds 2 and 3 (each within the scatter of the next).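

In this assay, the step from 1,3-thiazol-5-yl to 1-methyl-1H-pyrazol-5-yl on the carbonyl carbon reads no change at the digits printed from compound 2 to compound 3 (within the scatter) and so brings no recovery at this position. Measured against the thiophen-2-yl amide, the same ring gives a 32-fold higher number from compound 1 to compound 3 (1.51 log units; beyond the scatter) and matches the loss already seen with the thiazole, so among these three rings only thiophen-2-yl gives the lower number. Nothing measured here explains why these rings differ.

Still open, from the compounds shown here alone, is whether a furan-2-yl or a plain phenyl ring on this carbonyl carbon would keep the number of compound 1 or lose it as compound 2 and compound 3 do.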